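This account rests on a few compounds, and the source may have more. Where it says the series, first, only, none or still open, it means among the compounds named here.

Three compounds have so far been tested in a functional assay on A-375 cells (Homo sapiens) for cytotoxicity, read by MTT assay, with a stated time of 72 h, tested at 1 uM; on this read-out lower numbers stand for less inhibition of growth and higher numbers for more inhibition of growth at the one concentration tested:

- compound 1, `Cc1cccc(/C(N)=N/NC(=S)N2CCCCC2)n1`, gives 49.9%
- compound 2, `Cc1cccc(/C(N)=N/NC(=S)N2CCCC2)n1`, gives 13.6%
- compound 3, `Cc1ccnc(/C(N)=N/NC(=S)N2CCCCC2)c1`, gives 33.5%

Compound 1 and compound 2 share one core and differ in a single place: pyrrolidin-1-yl in place of piperidin-1-yl on a thiocarbonyl carbon. That one change produced a number 36.3 percentage points lower from compound 1 to compound 2 (beyond the scatter), a large drop, so with the smaller ring far fewer cells were held back at the tested concentration.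

Compound 3 is built from the same atoms as compound 1, joined differently; the difference between the two cores is not broken down here. In this assay compound 3 sits second of the three numbers, beyond the scatter from both of the others.

Compound 4, `Cc1ccnc(/C(N)=N/NC(=S)N2CCCC2)c1`, has not yet been measured. It stands to compound 3 exactly as compound 2 stands to compound 1: pyrrolidin-1-yl in place of piperidin-1-yl on a thiocarbonyl carbon. The surroundings of the changed spot are described in the same words for both pairs, so this is the same change, made twice among these four compounds.

A drop is therefore expected again. The size of the earlier drop is known because a number 36.3 percentage points lower from compound 1 to compound 2 (beyond the scatter) was measured directly. Compound 3 starts lower, at 33.5%, which leaves less room to fall before the read-out reaches no measurable inhibition. The expected step for compound 4 is a number 25.5 percentage points lower from compound 3 to compound 4 (beyond the scatter). Compound 4 is thus estimated to give 8%, most likely somewhere between -5% and 25%.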

Compound 4, percent growth inhibition at one concentration: 69%
Estimate against measurement, compound 4: 61 percentage points below, and the stated range ends below it.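

In this assay, putting pyrrolidin-1-yl in place of piperidin-1-yl on the core of compound 3 gave a number 35.5 percentage points higher from compound 3 to compound 4 (beyond the scatter), the opposite of what the same change did on the core of compound 1. The two steps are of similar size but point in opposite directions, so in this series the effect of this ring swap cannot be carried from one core to the other, and the result of the swap depends on the core it is made on: the same change on two cores in this assay, a number 36.3 percentage points lower (beyond the scatter) from compound 1 to compound 2 and a number 35.5 percentage points higher (beyond the scatter) from compound 3 to compound 4, 71.8 percentage points apart, beyond the scatter of two such steps. Going by these compounds alone, this does not show why the direction reverses, and with only two pairs, each read at a single concentration in one cell line, it gives no rule for which way the same change would go on any further core.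

The compounds shown carry only piperidin-1-yl and pyrrolidin-1-yl on the thiocarbonyl carbon, so it remains open how a morpholin-4-yl ring, an azepan-1-yl ring or an open-chain dimethylamino group would behave on these two cores. As far as these compounds go, it is also open whether the reversal would persist across a full range of concentrations rather than at the one tested here.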